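This account rests on a few compounds, and the source may have more. Where it says the series, first, only, none or still open, it means among the compounds named here.

Compound 3 `CCCCCCCOc1ccc(CC[C@@](N)(CO)CCC)cc1` holds the second highest of the three numbers in a functional assay on the whole organism (spleen, spleen) with Rattus norvegicus as the target (a higher number here means that more compound is needed for the effect, a lower number that less compound is needed), where compound 3 gives 4.4 mg/kg. Its nearest neighbour is compound 2 `CCCCCCCOc1ccc(CCC(N)(CO)C(C)C)cc1`, which gives 4.5 mg/kg, the two separated by a 1.0-fold lower number from compound 2 to compound 3 (0.01 log units; within the scatter). The furthest is compound 1 `CCCCCCCOc1ccc(CCC(N)(CO)CO)cc1`, which in this assay gives 0.014 mg/kg; the gaps are a 310-fold higher number from compound 1 to compound 3 (2.50 log units; beyond the scatter) and a 320-fold higher number from compound 1 to compound 2 (2.51 log units; beyond the scatter). Compound 4 `CCCCCCCOc1ccc(CC[C@](N)(CO)CCO)cc1` differs from compound 3 as follows: a group of 7 heavy atoms (4 carbon, 1 nitrogen, 2 oxygen; no ring) in place of a group of 7 heavy atoms (5 carbon, 1 nitrogen, 1 oxygen; no ring), on a saturated chain carbon, two bonds along the chain from an aromatic carbon. The steps from compound 1 show how much the second hydroxymethyl carried; compound 4 restores an oxygen, though not in the same group, so compound 4 is expected to improve by a 4.4-fold lower number from compound 3 to compound 4 (0.64 log units; beyond the scatter) in this assay. Compound 4 is therefore estimated at 1 mg/kg, with a range from 0.1 mg/kg to 5 mg/kg.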

Compound 4, dose for 50% inhibition: 4.2 mg/kg
Estimate against measurement, compound 4: 4.2-fold (0.62 log units) below; the measured number falls inside the stated range.
By their numbers in this assay, from the lowest: compound 1; then compounds 4, 3 and 2 (each within the scatter of the next).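

In this assay, a group with 2 oxygen in place of one with 1 oxygen, on a saturated chain carbon, two bonds along the chain from an aromatic carbon, brings no change beyond the scatter: there is a 1.0-fold lower number from compound 3 to compound 4 (0.02 log units; within the scatter) and a 1.1-fold lower number from compound 2 to compound 4 (0.03 log units; within the scatter). Within the data shown here, the group in compound 4 has as many oxygen atoms as the one in compound 1, yet there remains a 300-fold higher number from compound 1 to compound 4 (2.48 log units; beyond the scatter), so oxygen count alone does not separate these compounds. Going by these compounds, whether an aminomethyl or methoxymethyl group would keep the low number of compound 1 stays open. Nothing available explains these results.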